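A few compounds are considered here, and "the series" means these few. Any claim that something is new, unique, unknown or untested is made for them only; others in the source may bear on it.

Working notes on the series.

Compound 3 `CCC[C@@]1(O)[C@@H](CO)O[C@@H](n2ccc(=O)[nH]c2=O)[C@@H]1O` is the reference point for this step. In a functional assay on L1210 cells (Mus musculus), read by MTT assay (on this read-out lower numbers stand for stronger inhibition and higher numbers for weaker inhibition), compound 3 returns only a limit, > 350000 nM. Compound 1 `C#CC[C@]1(O)[C@@H](CO)O[C@@H](n2ccc(=O)[nH]c2=O)[C@@H]1O` likewise returns only a limit in this assay, > 350000 nM. Among the compounds with values here, compound 2 `C=C[C@@]1(O)[C@@H](CO)O[C@@H](n2ccc(N)nc2=O)[C@@H]1O` is the one member with a numerical reading, giving 60800 nM in this assay. So compound 3 sits at the limit together with compound 1, and no step between measured compounds is available in this assay; the one recurring feature is the limit of > 350000 nM in this assay, at which 2 of the 3 values shown sit.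

Compound 4 `CCC#C[C@@]1(O)[C@@H](CO)O[C@@H](n2ccc(=O)[nH]c2=O)[C@@H]1O` differs from compound 3 by but-1-yn-1-yl in place of propyl on a saturated ring carbon. Since compound 3 is known only as a limit, the size of the step cannot be read from any measured pair; the expectation is that compound 4 stays at or near the limit, with a step of a number no higher from compound 3 to compound 4 (the limit leaves the size open) that is most likely none beyond the scatter. Compound 4 is therefore estimated at 350000 nM in this assay, within 100000 nM to 1000000 nM, and a further limit rather than a number is the more probable outcome.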

Compound 4, half-maximal inhibitory concentration: 338000 nM
The estimate for compound 4 lay 1.0-fold (0.02 log units) above the measured number; low and high end bracket the measured number.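

Within the data shown here, with but-1-yn-1-yl in place of propyl on this saturated ring carbon, compound 4 gives a true number in this assay, 338000 nM, the first reading at this position for a compound sharing the base of compound 1 and compound 3. The change reads only as an at least 1.0-fold lower number from compound 3 to compound 4 (0.01 log units; that floor lies within the scatter), so it shows no gain beyond the scatter, and the alkyne-bearing chain gives no clear separation from propyl. Compound 1 and compound 3 remain at a single limit, which is a limit and not a number: the limit of > 350000 nM in this assay, at which 2 of the 4 values shown sit.

The true distance between compound 3 and compound 4 cannot be read, and compound 2 differs from the others in more than one place, so it does not settle the role of this position. Going by these compounds, whether an aminomethyl group or a longer chain such as hex-1-yn-1-yl on this ring carbon would give a lower number stays open.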